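This account rests on a few compounds, and the source may have more. Where it says the series, first, only, none or still open, it means among the compounds named here.

Measured so far in a functional assay on the whole organism (B cells) with Mus musculus as the target; on this read-out lower numbers stand for smaller maximal responses and higher numbers for larger maximal responses:
compound 1, `Nc1nc(O)c2c(n1)n(C1OC(CO)[C@@H](O)[C@H]1O)c(=O)n2Cc1ccc(Cl)c(Cl)c1`, gives 55%
compound 2, `Nc1nc(O)c2c(n1)n(C1OC(CO)[C@@H](O)[C@H]1O)c(=O)n2CC(O)CO`, gives 136%
compound 3, `CCOC(=O)Cn1c(=O)n(C2OC(CO)[C@@H](O)[C@H]2O)c2nc(N)nc(O)c21`, gives 86%

Compound 3 stands second highest of the three numbers. The step of a number 31 percentage points higher from compound 1 to compound 3 (beyond the scatter) places compound 3 well above compound 1, and the step of a number 50 percentage points lower from compound 2 to compound 3 (beyond the scatter) places it well below compound 2; both steps lie beyond the scatter, so the three compounds are clearly separated in this assay.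

Compound 4, `Nc1nc(O)c2c(n1)n(C1OC(CO)[C@@H](O)[C@H]1O)c(=O)n2Cc1ccc(Cl)cc1`, differs from compound 3 by 4-chlorophenyl in place of ethoxycarbonyl on a saturated chain carbon bound to an aromatic nitrogen. The change moves back toward compound 1, which carries 3,4-dichlorophenyl at the same place and gave the lowest number of the set. Within the data shown here, the steps that bear on it are therefore a number 31 percentage points higher from compound 1 to compound 3 (beyond the scatter) and, more distantly, a number 81 percentage points higher from compound 1 to compound 2 (beyond the scatter): both show that an aromatic chlorinated group at this place goes with a smaller maximal response than either open-chain group. Compound 4 carries one chlorine fewer than compound 1, so the return need not be complete. A step down beyond the scatter is expected, a number 24 percentage points lower from compound 3 to compound 4 (beyond the scatter). Compound 4 is estimated at 62%, with a range from 45% to 85%.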

Compound 4, largest response reached (reported as maximal response), in percent of the reference or control that the assay uses: 15%
The estimate for compound 4 lay 47 percentage points above the measured number, and the stated range ends above it.
By their numbers in this assay, from the lowest: compound 4; then compound 1; then compound 3; then compound 2.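

In this assay, among these compounds, the chlorinated aromatic groups no longer read as one class at this place: hydrogen in place of chloro on an aromatic carbon is itself a large step (a number 40 percentage points lower from compound 1 to compound 4 (beyond the scatter)). 4-Chlorophenyl now marks the low end of the set, well under both open-chain groups (a number 71 percentage points lower from compound 3 to compound 4 (beyond the scatter); a number 121 percentage points lower from compound 2 to compound 4 (beyond the scatter)), so the span across this place is wider than the earlier compounds showed. No measured evidence bears on why this one chloro changes the maximal response so strongly.

The compounds shown leave open where an unsubstituted phenyl group would fall, and whether the drop with 4-chlorophenyl belongs to that group alone. Also open, going by these compounds, is whether a carboxylic acid at the same place would stand nearer ethoxycarbonyl or 1,2-dihydroxyethyl.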